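A few compounds are considered here, and "the series" means these few. Any claim that something is new, unique, unknown or untested is made for them only; others in the source may bear on it.

Of the compounds shown here, three sharing one core have been tested in a functional assay on NCI/ADR-RES cells (Homo sapiens) for inhibition, read by sulforhodamine B assay, with a stated time of 48 h; a higher number here means that more compound is tolerated, a lower number that less compound is tolerated. Compound 1 `Nc1cc(N)c2nc(-c3ccccc3)c(Oc3ccc(Cl)c(Cl)c3)nc2c1` carries a 3,4-dichlorophenoxy group; in this assay compound 1 gives < 100000 nM, which is a limit of the assay rather than a number. Compound 3 `Nc1cc(N)c2nc(-c3ccccc3)c(Sc3ccc(Cl)c(Cl)c3)nc2c1`, with (3,4-dichlorophenyl)sulfanyl in place of 3,4-dichlorophenoxy on an aromatic carbon, likewise returns a limit: in this assay compound 3 gives < 100000 nM. Within the data shown here, the only step between measured compounds that differ in one place, a step that the two limits leave unreadable from compound 1 to compound 3, therefore cannot be read. Compound 2 `Nc1cc(N)c2nc(-c3ccccc3)c(NCc3ccc(Cl)c(Cl)c3)nc2c1` bears the 3,4-dichlorophenyl on a saturated chain carbon bound to a nitrogen on an aromatic ring; in this assay compound 2 gives < 100000 nM, again a limit. Among the measured compounds shown here, all three values sit at the same place, (the limit of < 100000 nM in this assay, at which 3 of the 3 values shown sit), so no measured step has a readable size and none bears directly on the change at hand. Compound 4 `COc1ccc(CNc2nc3cc(N)cc(N)c3nc2-c2ccccc2)cc1OC` is not yet measured; it differs from compound 2 by 3,4-dimethoxyphenyl in place of 3,4-dichlorophenyl on a saturated chain carbon bound to a nitrogen on an aromatic ring. With no readable step to lean on, the expected step is a step that the limit leaves unreadable from compound 2 to compound 4, nothing beyond the scatter. Compound 4 is accordingly estimated at 50000 nM, with a range from 10000 nM to 100000 nM, and it is expected most likely to return only a limit again in this assay.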

Compound 4, concentration lethal to 50% of the cells: < 100000 nM
Compound 4 gave a limit, no number; the forecaster's own chance of this, stated with the estimate: 70%; the middle value lies beyond the limit too.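

The step from compound 2 to compound 4 cannot be read, because both values are limits of the assay and neither is a number: the limit of < 100000 nM in this assay, at which 4 of the 4 values shown sit.

The compounds shown leave open where any of the four truly lies in this assay, and whether 3,4-dimethoxyphenyl and 3,4-dichlorophenyl differ there at all.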